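Swapping fluorine for chlorine on a growth-inhibiting scaffold

A few compounds are considered here, and "the series" means these few. Any claim that something is new, unique, unknown or untested is made for them only; others in the source may bear on it.

Of the compounds shown here, three have been measured in a functional assay on DU-145 cells (Homo sapiens) for inhibition, read by trypan blue exclusion, with a stated time of 96 h; on this read-out higher numbers stand for weaker inhibition of growth and lower numbers for stronger inhibition of growth. Compound 1 `COc1ccc(/C=C(/SCc2ccc(Cl)cc2)C(=O)c2ccc(Br)cc2)cc1` gives 10000 nM in this assay, and compound 2 `COc1ccc(/C=C(/SCc2ccc(F)cc2)C(=O)c2ccc(Br)cc2)cc1` gives 50000 nM. The two differ in one place only, namely (chloro in place of fluoro on an aromatic carbon), and this change made a step of a 5.0-fold lower number from compound 2 to compound 1 (0.70 log units; beyond the scatter). Compound 3 `O=C(O)c1ccc(C(=O)/C(=C\c2ccc(F)c([N+](=O)[O-])c2)SCc2ccc(C(F)(F)F)cc2)cc1` gives 1000 nM, the lowest of the three numbers, and its steps to compound 1 and to compound 2 both lie beyond the scatter. The difference between the core of compound 3 and the core of compound 2 is not broken down here.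

Compound 4 `O=C(O)c1ccc(C(=O)/C(=C\c2ccc(Cl)c([N+](=O)[O-])c2)SCc2ccc(C(F)(F)F)cc2)cc1` has not yet been measured in this assay. It differs from compound 3 by chloro in place of fluoro on an aromatic carbon. For the measured compounds named here, this is the same kind of change as the one from compound 2 to compound 1, but not the same change: in compound 3 the place is ortho to a nitro group and para to a large group, whereas in compound 2 the place is para to a large group only. With a single earlier pair to go on, and with different surroundings around the place, a smaller step is expected this time. Compound 4 is expected to give 500 nM, a step of a 2.0-fold lower number from compound 3 to compound 4 (0.30 log units; within the scatter). The estimated range for compound 4 runs from 150 nM to 1500 nM. This expectation rests on compound 3, which gives 1000 nM, and on the earlier step of a 5.0-fold lower number from compound 2 to compound 1 (0.70 log units; beyond the scatter).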

Compound 4, concentration for 50% growth inhibition: 1000 nM
Beside the measured number, compound 4's estimate is 2.0-fold (0.30 log units) below it, within the range that was stated.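

In this assay, the change from 4-fluoro-3-nitrophenyl to 4-chloro-3-nitrophenyl gave no change at the digits printed from compound 3 to compound 4 (within the scatter). Chloro in place of fluoro therefore did not bring the same result on the two cores, and the gap between the two steps is larger than repeated measurement alone would be expected to produce: the same change on two cores in this assay, a 5.0-fold lower number (0.70 log units; beyond the scatter) from compound 2 to compound 1 and no change at the digits printed (within the scatter) from compound 3 to compound 4, 5.0-fold (0.70 log units) apart, beyond the scatter of two such steps

For the compounds shown here, this shows that, in this series, the size of the step seen on one core cannot simply be carried over to another, but it rests on only one pair of compounds per core, and those cores differ in several places at once, so it does not show which difference matters, nor does it show how the change would behave on any further core.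

From the compounds shown here alone, it remains open whether the step would return if an amine took the place of the nitro group in compound 4, which would show whether that neighbouring group is tied to the result. Going by these compounds, it is also open how the number would move with a methyl group or a nitrile at the place now held by chloro, and whether a carboxylic acid on the core of compound 1 would alter the step seen there.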